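The compounds below may be only part of what the source reports. "The series", "measured", "known", "first", "only" and "open" are said of these compounds alone.

Compound 1 `CC(C)[C@@H]1CC[C@@H](C)C[C@@]12N(C)C(=O)[C@@H]1[C@H]3C(=O)N(c4ccccc4)C(=O)[C@H]3ON12`: 35.4%
Compound 2 `CC(C)[C@@H]1CC[C@@H](C)C[C@@]12N(C)C(=O)[C@@H]1[C@H]3C(=O)N(c4ccc(Cl)cc4)C(=O)[C@H]3ON12`: 53.7%

In a functional assay, read by spectrophotometry, with a stated time of 2 h, tested at 1 mg/mL (a higher number here means a stronger effect of the compound at the concentration tested, a lower number a weaker effect), compound 1 gives 35.4%, the lowest of the two numbers; the nearest is compound 2, which gives 53.7%. Compound 3 `COc1ccc(N2C(=O)[C@H]3[C@H](ON4[C@@H]3C(=O)N(C)[C@@]43C[C@H](C)CC[C@H]3C(C)C)C2=O)cc1` differs from compound 1 by methoxy in place of hydrogen on an aromatic carbon. Among the measured compounds shown here, the one measured step that bears on this is the change at the same aromatic carbon, a number 18.3 percentage points higher from compound 1 to compound 2 (beyond the scatter). A different group enters here, so a smaller rise is expected for compound 3 than that step, yet still upward, giving an estimated a number 8.6 percentage points higher from compound 1 to compound 3 (within the scatter). Compound 3 is therefore expected to give 44%, within 28% to 60%.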

Compound 3, a percentage reported as activity, at one concentration (the size of the read-out at that concentration, not a potency): 50%
The estimate for compound 3 lay 6 percentage points below the measured number; low and high end bracket the measured number.
By their numbers in this assay, from the lowest: compound 1; then compounds 3 and 2 (each within the scatter of the next).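

Methoxy on this aromatic carbon, para to a large group, gives a number 14.6 percentage points higher from compound 1 to compound 3 (beyond the scatter) in this assay, so the rise at this position is not confined to chloro. Replacing chloro with methoxy gives a number 3.7 percentage points lower from compound 2 to compound 3 (within the scatter), so compound 2 and compound 3 cannot be told apart here. Nothing measured accounts for why these two different groups read alike. Going by these compounds, whether an amine, a carboxylic acid or a longer chain such as butoxy at this position would also raise the read-out remains open.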